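Swapping the Acyl Group on Compound 2

A few compounds are considered here, and "the series" means these few. Any claim that something is new, unique, unknown or untested is made for them only; others in the source may bear on it.

Measured compounds in an assay on HEK293 cells for negative allosteric modulation of metabotropic glutamate receptor 5 (Homo sapiens), read by FLIPR, with a stated time of 1 h; a higher number here means a weaker inhibitor, a lower number a stronger inhibitor:
Compound 1 `Fc1cccc(C#Cc2nc3c(s2)CN(C2CCOC2)CC3)c1`: compound 1 gives 400 nM.
Compound 2 `CC1CC1C(=O)N1CCc2nc(C#Cc3ccccc3)sc2C1`: compound 2 gives > 10000 nM, a limit of the assay.
Compound 3 `O=C(C1CC(F)(F)C1)N1CCc2nc(C#Cc3cccc(F)c3)sc2C1`: compound 3 gives > 10000 nM, also a limit.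

Compound 2 thus stands at the limit of > 10000 nM in this assay, at which 2 of the 3 values shown sit. Among the compounds with values here, the only measured step, an at least 25-fold higher number from compound 1 to compound 3 (1.39 log units; beyond the scatter), swaps a group on an amine nitrogen in a ring for an acyl group and does not bear on the change at hand. Compound 4 `O=C(c1cccc(Cl)c1)N1CCc2nc(C#Cc3ccccc3)sc2C1` differs from compound 2 in that (3-chlorophenyl in place of 2-methylcyclopropyl on a carbonyl carbon). Within the data shown here, no measured step covers this exchange, and both acylated compounds sit at the limit, so no direction beyond the scatter is expected. Compound 4 is expected to remain weak, with an estimated step of an at least 1.2-fold lower number from compound 2 to compound 4 (0.09 log units; that floor lies within the scatter). The estimate for compound 4 is 8000 nM, expected between 2000 nM and 30000 nM.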

Compound 4, half-maximal inhibitory concentration: > 10000 nM
Compound 4: no number, only a limit; the forecaster's own chance of this, stated with the estimate: 55%; middle value at least 1.2-fold (0.09 log units) away from the limit.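

In this assay compound 4 gives > 10000 nM, a limit of the assay. Within the data shown here, compound 2 also sits at a limit, and no step between compound 2 and compound 4 can be read. Going by these compounds, whether 3-chlorophenyl or 2-methylcyclopropyl on the carbonyl carbon gives the stronger inhibitor stays open.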